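This account rests on a few compounds, and the source may have more. Where it says the series, first, only, none or still open, it means among the compounds named here.

Measured so far:
compound 1 `CC(C)c1nc(C(=O)NCC2CCN(C3CCC3)CC2)c2ccccn12` — 9.8 nM
compound 2 `COCCCN1CCC(O)(CNC(=O)c2nc(C(C)C)n3ccccc23)CC1` — 316 nM

Both compounds were run in a functional assay on CHO cells for agonist activity at 5-hydroxytryptamine receptor 4 (Homo sapiens), read by a luciferase reporter and cAMP accumulation, with a stated time of 4 h; on this read-out lower numbers stand for an effect already at smaller amounts and higher numbers for an effect only at larger amounts of compound. Compound 1 gives 9.8 nM and compound 2 gives 316 nM, so compound 2 stands at the higher of the two numbers, and the gap between the two is beyond the scatter. The two compounds differ in more than one place, so nothing beyond the two values themselves can be read from that pair.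

Compound 3 `CC(C)c1nc(C(=O)NCC2(O)CCN(CC3CCOCC3)CC2)c2ccccn12` has not yet been measured. It differs from compound 2 in one place: oxan-4-yl in place of 2-methoxyethyl on a saturated chain carbon bound to an amine nitrogen in a ring. The change closes a short chain into a saturated ring while keeping one hydrogen-bond acceptor and no donor, and it leaves the hydroxylated ring and the amide of compound 2 in place. Among the compounds with values here, no step of this kind stands among the measured compounds, so the expectation rests only on the position of compound 2 in this assay and on the size of the change. A modest move toward a lower number is expected, of a size that may not clear the scatter, with the estimated step from compound 2 to compound 3 being a 1.8-fold lower number from compound 2 to compound 3 (0.24 log units; within the scatter). For compound 3 in this assay the expected value is 180 nM, with a range from 45 nM to 700 nM.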

Compound 3, half-maximal effective concentration: 56.7 nM
Compound 3: middle estimate off by 3.2-fold (0.50 log units), on the high side; the measured number falls inside the stated range.
By their numbers in this assay, from the lowest: compound 1; then compound 3; then compound 2.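

In this assay, within the data shown here, the substituent on a saturated chain carbon bound to an amine nitrogen in a ring proves able to shift the read-out: oxan-4-yl in place of 2-methoxyethyl gives a 5.6-fold lower number from compound 2 to compound 3 (0.75 log units; beyond the scatter) in the first single-place comparison of the series. The two groups match in hydrogen-bond donors and acceptors and carry no net charge, so these counts do not distinguish them; they differ in the six-membered non-aromatic ring and in heavy atoms, 6 against 4. Cut one bond further out, the same change reads 3-methoxypropyl to (oxan-4-yl)methyl, and no measurement here separates the contribution of the ring from that of the added atoms.

Still open, as far as these compounds go, is whether the ring oxygen matters at this place, a question that cyclohexyl, with carbon in its place, or oxetan-3-yl, with a smaller ring, would address. Also open, from the compounds shown here alone, is whether the step carries over to a compound without the hydroxyl group, since this single pair shows the change only with that group in place.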